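A few compounds are considered here, and "the series" means these few. Any claim that something is new, unique, unknown or untested is made for them only; others in the source may bear on it.

Compound 1 `CCCCCCCCC(=O)c1cc(O)c(O)c(O)c1`: 22000 nM
Compound 2 `CCCCCCCCCCC(=O)c1cc(O)c(O)c(O)c1`: 12200 nM
Compound 3 `CCCCCCCCCCCCC(=O)c1cc(O)c(O)c(O)c1`: 10900 nM

All three share one core and differ only in the length of the saturated chain attached to the carbonyl. In a functional assay on L1210 cells (Mus musculus) for cytotoxicity, read by MTT assay, with a stated time of 48 h (a higher number here means a weaker inhibitor, a lower number a stronger inhibitor), compound 1 gives 22000 nM, compound 2 gives 12200 nM and compound 3 gives 10900 nM. Compound 3 has the lowest of the three numbers, but its nearest neighbour, compound 2, is only a 1.1-fold lower number from compound 2 to compound 3 (0.05 log units; within the scatter) away, and even the step from the highest number is modest: a 2.0-fold lower number from compound 1 to compound 3 (0.30 log units; within the scatter). Both lie within the scatter, so compound 3 cannot be called the strongest inhibitor on these data alone.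

Compound 4 `CCCCCCCCCCCCCCC(=O)c1cc(O)c(O)c(O)c1` is not yet measured. Compared with compound 3 it carries ethyl in place of hydrogen on a saturated chain carbon, ten or more bonds along the chain from a carbonyl carbon.

The most direct precedent is the step from compound 2 to compound 3, which is the same kind of change and gave a 1.1-fold lower number from compound 2 to compound 3 (0.05 log units; within the scatter). The earlier step of a 1.8-fold lower number from compound 1 to compound 2 (0.26 log units; within the scatter) points in the same direction but also stays within the scatter. The expectation is therefore a number close to that of compound 3, with at most a small lowering: a 1.1-fold lower number from compound 3 to compound 4 (0.06 log units; within the scatter) is the estimated step. For compound 4 the expected value in this assay is 9500 nM, with a likely range from 5000 nM to 19000 nM.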

Compound 4, half-maximal inhibitory concentration: 8500 nM
Compound 4: the middle estimate sits 1.1-fold (0.05 log units) above what was measured; low and high end bracket the measured number.
By their numbers in this assay, from the lowest: compounds 4, 3, 2 and 1 (each within the scatter of the next, the first and the last beyond it).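

Ethyl in place of hydrogen on a saturated chain carbon again stays within the scatter in this assay at a 1.3-fold lower number from compound 3 to compound 4 (0.11 log units; within the scatter), and butyl at that place does too, at a 1.4-fold lower number from compound 2 to compound 4 (0.16 log units; within the scatter). Going by these compounds alone, what the earlier compounds could not show is a difference between chain lengths that clears the scatter: hexyl in place of hydrogen, eight bonds along the chain from the carbonyl carbon, gives a 2.6-fold lower number from compound 1 to compound 4 (0.41 log units; beyond the scatter), a modest step that appears only across the full span of the series. The ethyl change also reads alike at two places along the chain, so the series gives no sign yet that this change behaves differently further out: the same change on two cores in this assay, a 1.8-fold lower number (0.26 log units; within the scatter) from compound 1 to compound 2 and a 1.3-fold lower number (0.11 log units; within the scatter) from compound 3 to compound 4, 1.4-fold (0.15 log units) apart, within the scatter of two such steps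

A longer chain than that of compound 4 could lower the number further or raise it, and a chain ending in an amine or a carboxylic acid could do either, and the compounds shown do not tell which. With each compound within the scatter of the next, they also cannot fix a chain length at which the number stops changing.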